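Changing the Aryl Group on the Ring Nitrogen

The source may report more compounds than this note shows. Statements on the series, on what has been measured and on what is new or still open speak of the compounds shown alone.

Three compounds have so far been measured in a functional assay on A-375 cells (Homo sapiens) for antiproliferative activity, read by MTT assay, with a stated time of 72 h; a higher number here means a weaker inhibitor, a lower number a stronger inhibitor:
compound 1 `COc1ncc(-c2ccc3c(c2)N(c2ccc(F)cc2)C(=O)CO3)cc1NS(=O)(=O)c1ccc(F)cc1` gives > 40000 nM, which is a limit of this assay rather than a number.
compound 2 `O=C1COc2ccc(-c3cnc(Cl)c(NS(=O)(=O)c4ccc(F)cc4)c3)cc2N1c1ccc(Cl)cc1` gives 30600 nM.
compound 3 `COc1ncc(-c2ccc3c(c2)N(c2ccc(Cl)cc2)C(=O)CO3)cc1NS(=O)(=O)c1ccc(F)cc1` gives 24100 nM.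

Compound 3 has the lower of the two numbers, but the gap between them is a 1.3-fold lower number from compound 2 to compound 3 (0.10 log units; within the scatter), so the two cannot be ranked. Compound 4 `COc1cccc(N2C(=O)COc3ccc(-c4cnc(OC)c(NS(=O)(=O)c5ccc(F)cc5)c4)cc32)c1` is the next step, with 3-methoxyphenyl in place of 4-chlorophenyl on an amide-type nitrogen in a ring. The measured step at that same place is an at least 1.6-fold lower number from compound 1 to compound 3 (0.22 log units; that floor lies within the scatter), and the step at the other ring is a 1.3-fold lower number from compound 2 to compound 3 (0.10 log units; within the scatter); neither leaves the scatter. A change of similar size, a 1.1-fold higher number from compound 3 to compound 4 (0.05 log units; within the scatter), is expected here. Compound 4 is therefore estimated at 27000 nM, within 11000 nM to 65000 nM.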

Compound 4, half-maximal inhibitory concentration: > 40000 nM
Compound 4: a limit, no number (the forecaster's own chance of this, stated with the estimate: 30%); middle value at least 1.4-fold (0.17 log units) from the limit.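

Putting 3-methoxyphenyl in place of 4-chlorophenyl on the ring nitrogen gives an at least 1.6-fold higher number from compound 3 to compound 4 (0.22 log units; that floor lies within the scatter), so this assay does not show that this swap weakens the compound. The step between compound 1 and compound 4 cannot be read, as both values are limits. Compound 4 reads only as a limit, the second compound at this position to do so: the limit of > 40000 nM in this assay, at which 2 of the 4 values shown sit.

This change alters both the group and where its substituent sits, and 4-methoxyphenyl would separate the two. From the compounds shown here alone, whether an amine on this aryl ring would give a clearly lower number remains open.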